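Swapping a Phenethyl Arm for a Methylphenyl Ring

This account rests on a few compounds, and the source may have more. Where it says the series, first, only, none or still open, it means among the compounds named here.

Measured so far:
Compound 1 `O=C1C[C@H](O)C[C@@H](/C=C/c2c(Cl)cc(Cl)cc2CCc2ccccc2)O1` — 430 nM
Compound 2 `O=C1C[C@H](O)C[C@@H](/C=C/c2c(F)cc(F)cc2-c2ccc(F)cc2)O1` — 860 nM
Compound 3 `O=C1C[C@H](O)CC(CCc2ccccc2-c2ccccc2)O1` — 44000 nM

These three compounds were tested in an assay for inhibition of 3-hydroxy-3-methylglutaryl-coenzyme A reductase (Rattus norvegicus); a higher number here means a weaker inhibitor, a lower number a stronger inhibitor. Compound 1 gives 430 nM, and compound 2 gives 860 nM, so the two cannot be told apart within the usual scatter. Compound 3, with 44000 nM, stands far weaker than either, well beyond the scatter.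

The unmeasured compound 4 `Cc1cccc(-c2cc(Cl)cc(Cl)c2/C=C/[C@@H]2C[C@@H](O)CC(=O)O2)c1` keeps the core of compound 1 and changes one group: 3-methylphenyl in place of phenethyl on an aromatic carbon. Within the data shown here, compound 2 is the only measured example carrying an aryl ring directly on the aromatic carbon, and its number sits within the scatter of compound 1, though it also differs from compound 1 in its halogens, so no clean step can be read from it. The expected change from compound 1 to compound 4 in this assay is therefore a 1.3-fold higher number from compound 1 to compound 4 (0.11 log units; within the scatter), a step not clearly beyond the scatter. Compound 4 is estimated at 550 nM in this assay, within a range from 150 nM to 2000 nM.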

Compound 4, half-maximal inhibitory concentration: 16 nM
The estimate for compound 4 lay 34-fold (1.54 log units) above the measured number; measured number below the stated range.
By their numbers in this assay, from the lowest: compound 4; then compounds 1 and 2 (each within the scatter of the next); then compound 3.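

Among these compounds, this change gives the first clean reading of the aromatic carbon that carries the phenethyl arm in compound 1. In this assay the exchange of phenethyl for 3-methylphenyl gives a 27-fold lower number from compound 1 to compound 4 (1.43 log units; beyond the scatter) and so shows that this position is highly sensitive to what it carries, even though both groups are made only of carbon, each holds one six-membered aromatic ring, and neither has hydrogen-bond donors or acceptors. Nothing shown here explains the size of this step.

A plain phenyl ring in this place would show whether the methyl group contributes to the step or the ring alone accounts for it. From the compounds shown here alone, how a longer chain or an amine would fare on this same aromatic carbon also remains open.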